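The compounds below may be only part of what the source reports. "The series", "measured", "known", "first", "only" and "open" are said of these compounds alone.

The measured compounds are three:

compound 1, `CCCNC(=O)c1ccc(Oc2nc(-c3c(C)noc3C)cnc2N)cc1`, 47800 nM
compound 2, `Cc1noc(C)c1-c1cnc(N)c(Oc2ccc(C(=O)Nc3cccc(Cl)n3)cc2)n1`, 64100 nM
compound 3, `Cc1noc(C)c1-c1cnc(N)c(Oc2ccc(C(=O)Nc3ccc(Cl)cn3)cc2)n1`, 45600 nM

All three values come from a functional assay on U-87MG ATCC cells for inhibition, with U-87 MG (Homo sapiens) as the target, read by MTT assay, with a stated time of 72 h; on this read-out higher numbers stand for weaker inhibition and lower numbers for stronger inhibition. Among them compound 1 stands second highest; its nearest neighbour is compound 3, with a 1.0-fold lower number from compound 1 to compound 3 (0.02 log units; within the scatter), and its furthest is compound 2, with a 1.3-fold higher number from compound 1 to compound 2 (0.13 log units; within the scatter), so that the three compounds sit within the scatter of one another and no order among them can be read from these numbers.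

Compound 4, `Cc1noc(C)c1-c1cnc(N)c(Oc2ccc(C(=O)Nc3ncccc3Cl)cc2)n1`, has not yet been measured. It differs from compound 1 in one place: 3-chloropyridin-2-yl in place of propyl on an amide-type nitrogen. Within the data shown here, the steps that bear on this change are the two already recorded from compound 1, a 1.3-fold higher number from compound 1 to compound 2 (0.13 log units; within the scatter) and a 1.0-fold lower number from compound 1 to compound 3 (0.02 log units; within the scatter), in which a chloropyridinyl group likewise entered on the amide-type nitrogen in place of propyl; the step between the two chloropyridinyl compounds, a 1.4-fold lower number from compound 2 to compound 3 (0.15 log units; within the scatter), was also within the scatter. On that basis no step beyond the scatter is expected in this assay for compound 4, and its estimate is a 1.0-fold higher number from compound 1 to compound 4 (0.02 log units; within the scatter). Compound 4 is therefore expected to give about 50000 nM, within a range from 25000 nM to 100000 nM.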

Compound 4, half-maximal inhibitory concentration: 45600 nM
Compound 4: the middle estimate sits 1.1-fold (0.04 log units) above what was measured, within the range that was stated.
By their numbers in this assay, from the lowest: compounds 3, 4, 1 and 2 (each within the scatter of the next).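

With 3-chloropyridin-2-yl in place of propyl on the amide-type nitrogen, this assay shows a 1.0-fold lower number from compound 1 to compound 4 (0.02 log units; within the scatter), so a third chloropyridinyl group now joins the other two in leaving the number within the scatter of the propyl amide. Among the chloropyridinyl groups themselves, 3-chloropyridin-2-yl in place of 5-chloropyridin-2-yl gives no change at the digits printed from compound 3 to compound 4 (within the scatter), and in place of 6-chloropyridin-2-yl it gives a 1.4-fold lower number from compound 2 to compound 4 (0.15 log units; within the scatter), so no order among the three placements of the chlorine can be read from these numbers. No measurement at hand offers an explanation for this flat picture.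

The compounds shown leave open whether any group on this nitrogen can take the number beyond the scatter, for example a pyridin-2-yl ring without chlorine, a longer chain, or a chain ending in an amine or a carboxylic acid. Every step shown falls at this one place, so they also say nothing about what a change elsewhere in the core of compound 1 would do.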